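The compounds below may be only part of what the source reports. "The series", "measured", "known", "first", "only" and "open" are said of these compounds alone.

Working notes on the series. In a functional assay on NCI-H226 cells (Homo sapiens) for inhibition, read by sulforhodamine B assay, with a stated time of 48 h, tested at 0.1 uM (on this read-out lower numbers stand for a stronger effect and higher numbers for a weaker effect at the one concentration tested), compound 1 `COc1cc(Cl)cc(-c2nn(-c3cccc(NC(=O)Nc4ccc(Cl)c(C(F)(F)F)c4)c3)cc2-c2ccncc2)c1` gives 96%, compound 2 `COc1cc(Cl)cc(-c2nn(-c3cccc(NC(=O)Nc4ccc(Cl)c(Cl)c4)c3)cc2-c2ccncc2)c1` gives 96%, and compound 3 `COc1cc(Cl)cc(-c2nn(-c3cccc(NC(=O)Nc4cccc(C(F)(F)F)c4)c3)cc2-c2ccncc2)c1` gives 95%. The three numbers sit close together: no change at the digits printed from compound 1 to compound 2 (within the scatter), a number 1 percentage points lower from compound 1 to compound 3 (within the scatter) and a number 1 percentage points lower from compound 2 to compound 3 (within the scatter). Compound 3 holds the lowest of the three numbers, but its gap to each of the others lies within the scatter, so no order among the three compounds can be read from these numbers.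

The next compound, compound 4 `COc1cc(Cl)cc(-c2nn(-c3cccc(NC(=O)c4cccc(C(F)(F)F)c4)c3)cc2-c2ccncc2)c1`, differs from compound 3 at the carbonyl: 3-(trifluoromethyl)phenyl in place of (3-(trifluoromethyl)phenyl)amino on a carbonyl carbon. None of the three measured steps touches the carbonyl carbon or the amide-type nitrogen; all three alter only the terminal aromatic ring, and all three stayed within the scatter. Within the data shown here, there is therefore no measured step that bears directly on this change, and the expectation for compound 4 in this assay rests on the three compounds all giving numbers close to one another.

For compound 4 the expected step is a number 1 percentage points lower from compound 3 to compound 4 (within the scatter), with nothing beyond the scatter anticipated. The estimate for compound 4 in this assay is 94%, in a range from 82% to 100%.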

Compound 4, a percentage reported as activity, at one concentration (the size of the read-out at that concentration, not a potency): 90%
The estimate for compound 4 lay 4 percentage points above the measured number; the range from low to high includes it.
By their numbers in this assay, from the lowest: compounds 4, 3, 1 and 2 (each within the scatter of the next).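

In this assay, among these compounds, this is the first change at the carbonyl carbon itself rather than on the terminal ring: 3-(trifluoromethyl)phenyl in place of (3-(trifluoromethyl)phenyl)amino, with the amino nitrogen and its hydrogen-bond donor gone, gives a number 5 percentage points lower from compound 3 to compound 4 (within the scatter) at the one concentration tested. The two wider comparisons, which also alter the terminal ring, read the same way: a number 6 percentage points lower from compound 2 to compound 4 (within the scatter) and a number 6 percentage points lower from compound 1 to compound 4 (within the scatter). No measurement here speaks to the origin of these numbers.

Open, going by these compounds, is whether a group of another kind on the carbonyl carbon, such as a morpholine, a carboxylic acid or a longer alkyl chain, would give a number beyond the scatter from compound 3. A single concentration also leaves open how the effect of all four compounds would compare at any other concentration.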